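Chloro to amino on the fused ring of compound 2

A few compounds are considered here, and "the series" means these few. Any claim that something is new, unique, unknown or untested is made for them only; others in the source may bear on it.

Measured compounds, with growth inhibition in a functional assay on MCF7 cells (Homo sapiens) for antiproliferative activity, read by sulforhodamine B assay, with a stated time of 48 h; on this read-out lower numbers stand for stronger inhibition of growth and higher numbers for weaker inhibition of growth:
compound 1 `Nc1nn(C(=O)Nc2ccc(Cc3ccccc3)cc2)c2ccccc12`: 555 nM
compound 2 `Nc1nn(C(=O)Nc2ccc(Cc3ccccc3)cc2)c2ccc(Cl)cc12`: 395 nM

Compound 2 carries a chloro on the fused ring where compound 1 has hydrogen; the step of a 1.4-fold lower number from compound 1 to compound 2 (0.15 log units; within the scatter) separates them, so the two numbers cannot be told apart and compound 2 stands nowhere clearly apart from compound 1 in this assay.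

Compound 3 `Nc1ccc2c(c1)c(N)nn2C(=O)Nc1ccc(Cc2ccccc2)cc1` is the next member: its change from compound 2 is amino in place of chloro on an aromatic carbon. For the measured compounds named here, the only measured step, from hydrogen to chloro at the same carbon, stayed within the scatter, and no measured pair shows what an amino at this carbon does. With nothing beyond the scatter on record, the expectation for compound 3 in this assay is a step of about a 1.3-fold higher number from compound 2 to compound 3 (0.10 log units; within the scatter), meaning no change beyond the scatter. Compound 3 is therefore estimated at 500 nM in this assay, with a range from 200 nM to 1500 nM.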

Compound 3, concentration for 50% growth inhibition: 6920 nM
Estimate against measurement, compound 3: 14-fold (1.14 log units) below, and the stated range ends below it.
By their numbers in this assay, from the lowest: compounds 2 and 1 (each within the scatter of the next); then compound 3.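

In this assay this carbon of the fused ring turns out not to be indifferent to its substituent: amino in place of chloro gives an 18-fold higher number from compound 2 to compound 3 (1.24 log units; beyond the scatter) and amino in place of hydrogen gives a 12-fold higher number from compound 1 to compound 3 (1.10 log units; beyond the scatter). Hydrogen and chloro at this carbon stayed within the scatter of each other, so the first large step in the series appears only with amino, and it is large whichever of the two earlier compounds serves as the reference. No measurement on hand accounts for this loss of growth inhibition.

The compounds shown leave open whether the loss belongs to the free amino group alone or extends to other groups at this carbon, such as hydroxyl, methoxy, dimethylamino or an acetylated amine, and whether bromo or fluoro would stay within the scatter of chloro and hydrogen. They also leave open whether amino on the other aromatic carbons of the six-membered ring would give a step of similar size.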